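Hydroxymethyl to Acetamido: Expecting the Next Number

A few compounds are considered here, and "the series" means these few. Any claim that something is new, unique, unknown or untested is made for them only; others in the source may bear on it.

Of the compounds shown here, three sharing one core have been measured in an ADME assay on isolated protein for inhibition of peroxidase (Raphanus sativus), read by fluorescence and Amplex Red, tested at 5 uM; on this read-out higher numbers stand for a weaker effect at the one concentration tested and lower numbers for a stronger effect. Compound 1 `Oc1ccccc1NC(=S)Nc1ccc2[nH]ccc2c1` gives 43.9%, compound 3 `CC(=O)c1ccc(NC(=S)Nc2ccc3[nH]ccc3c2)cc1` gives 66.3%, and compound 2 `OCc1ccc(NC(=S)Nc2ccc3[nH]ccc3c2)cc1` gives 88.3%, the highest of the three and therefore the weakest effect at this concentration. Among the measured compounds shown here, the only single-change comparison available is a number 22 percentage points lower from compound 2 to compound 3 (beyond the scatter). Compound 4 `CC(=O)Nc1ccc(NC(=S)Nc2ccc3[nH]ccc3c2)cc1` differs from compound 2 by acetamido in place of hydroxymethyl on an aromatic carbon. Acetyl in place of hydroxymethyl lowered the number beyond the scatter; acetamido, like acetyl, carries a double bond outside aromatic rings, but no measured step involves acetamido itself, so the guide is indirect. A modest decrease is therefore expected, a number 13.3 percentage points lower from compound 2 to compound 4 (beyond the scatter). Compound 4 is expected to give 75%, estimated within a range from 55% to 92%.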

Compound 4, a percentage reported as activity, at one concentration (the size of the read-out at that concentration, not a potency): 68.1%
Compound 4: middle estimate off by 6.9 percentage points, on the high side; the range from low to high includes it.
By their numbers in this assay, from the lowest: compound 1; then compounds 3 and 4 (each within the scatter of the next); then compound 2.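

In this assay, acetamido on this aromatic carbon, para to a large group, gives a number 20.2 percentage points lower from compound 2 to compound 4 (beyond the scatter), so a second replacement for hydroxymethyl also lowers the number. Between the two replacements there is a number 1.8 percentage points higher from compound 3 to compound 4 (within the scatter), so this read-out does not separate acetamido from acetyl at this position. Nothing available explains why either group differs from hydroxymethyl. Still open, going by these compounds, is whether an amine or a carboxylic acid on this carbon would read like acetyl and acetamido or like hydroxymethyl.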